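Methoxy for Fluoro on the Benzyl Arm

The compounds below may be only part of what the source reports. "The series", "measured", "known", "first", "only" and "open" are said of these compounds alone.

Within the data shown here, compound 1 `OC[C@H]1O[C@@H](n2cnc3c(NCc4cccc(F)c4)ncnc32)[C@H](O)[C@@H]1O` is the one member of this small set that gives a number in an ADME assay on NIH3T3 cells (Mus musculus) for cytotoxicity, with a stated time of 72 h; a higher number here means a weaker inhibitor, a lower number a stronger inhibitor: compound 1 gives 84000 nM. Compound 2 `OC[C@H]1O[C@@H](n2cnc3c(NCc4ccccc4Cl)ncnc32)[C@H](O)[C@@H]1O` gives only > 166000 nM in this assay, a limit rather than a number. Compound 3 `OC[C@H]1O[C@@H](n2cnc3c(NCc4ccccc4Br)ncnc32)[C@H](O)[C@@H]1O` likewise gives > 166000 nM in this assay, again a limit. The set is thus shaped by the limit of > 166000 nM in this assay, at which 2 of the 3 values shown sit, and the two steps away from compound 1 read only as floors: an at least 1.9-fold higher number from compound 1 to compound 2 (0.29 log units; that floor lies within the scatter) with 2-chlorophenyl in place of 3-fluorophenyl, and an at least 1.9-fold higher number from compound 1 to compound 3 (0.29 log units; that floor lies within the scatter) with 2-bromophenyl in place of 3-fluorophenyl, while a step that the two limits leave unreadable from compound 2 to compound 3, bromo in place of chloro on an aromatic carbon.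

Compound 4 `COc1cccc(CNc2ncnc3c2ncn3[C@@H]2O[C@H](CO)[C@@H](O)[C@H]2O)c1` keeps the shared core of compound 1 and differs by methoxy in place of fluoro on an aromatic carbon, that is, 3-fluorobenzyl becomes 3-methoxybenzyl. Among the measured compounds shown here, no measured step exchanges a fluoro for a methoxy, and the steps that do exist from compound 1 all end at a limit, so they tell direction only weakly and size not at all. The author therefore expects, for compound 4 in this assay, no step beyond the scatter, with a fair chance that the read-out is again a limit. Compound 4 is estimated at 110000 nM, within 40000 nM to 300000 nM. This estimate means a step of a 1.3-fold higher number from compound 1 to compound 4 (0.12 log units; within the scatter).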

Compound 4, half-maximal inhibitory concentration: > 166000 nM
Compound 4: no number, only a limit (the forecaster's own chance of this, stated with the estimate: 40%); at least 1.5-fold (0.17 log units) between middle value and limit.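

In this assay, among these compounds, the exchange at this aromatic carbon reads as an at least 1.9-fold higher number from compound 1 to compound 4 (0.29 log units; that floor lies within the scatter) and nothing more, so the first fluoro-to-methoxy change on this arm gives a direction that the scatter cannot confirm and no size. Among the compounds shown here, what the earlier compounds could not show is that a group kept at the same place on the ring as the fluoro of compound 1 can also end at a limit, so that limit is no longer confined to the 2-chlorophenyl and 2-bromophenyl arms of compound 2 and compound 3. For the compounds shown here, compound 1 is now the only compound with a number, and the steps among compound 2, compound 3 and compound 4 cannot be read, the shape of the set being set by one limit: the limit of > 166000 nM in this assay, at which 3 of the 4 values shown sit.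

On these data alone, how far compound 2, compound 3 and compound 4 actually lie from that limit stays unknown, so the three arms cannot be ranked against one another. As far as these compounds go, it also stays open whether an amine, a carboxylic acid or a longer chain such as ethoxy in place of the fluoro would give a number or again a limit.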